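A few compounds are considered here, and "the series" means these few. Any claim that something is new, unique, unknown or untested is made for them only; others in the source may bear on it.

Compound 3, `N#Cc1ccc2ccc(C(=O)c3ccc(F)c(O)c3)nc2c1`, gives the lowest number of the three compounds measured in an assay for binding affinity to 17-beta-hydroxysteroid dehydrogenase 14 (Homo sapiens), read by fluorescence, with a stated time of 15 min, in the presence of a further agent that is not named here (on this read-out lower numbers stand for stronger inhibition and higher numbers for weaker inhibition), at 9 nM. Compound 1, `O=C(c1ccc(F)c(O)c1)c1ccc2cc(O)ccc2n1`, is the nearest to it and gives 119 nM in this assay. Compound 2, `O=C(Nc1cccc(-c2cccc(O)c2F)n1)c1ccc(F)c(O)c1`, stands furthest away and gives 686 nM in this assay. Both gaps to compound 3 lie beyond the usual scatter, so compound 3 is the most potent of the three on the numbers shown.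

Compound 4, `Nc1ccc2ccc(C(=O)c3ccc(F)c(O)c3)nc2c1`, has not yet been measured. It differs from compound 3 in one place: amino in place of cyano on an aromatic carbon. Within the data shown here, no pair of measured compounds differs in exactly this way, so the size of the step cannot be read from the data, and the expectation rests on the position of compound 3 alone. Compound 4 is expected to give a weaker result than compound 3, by a step of a 4.4-fold higher number from compound 3 to compound 4 (0.65 log units; beyond the scatter), a moderate shift that may or may not clear the scatter. Compound 4 is therefore estimated at 40 nM in this assay, within a range from 10 nM to 160 nM.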

Compound 4, inhibition constant: 34 nM
Estimate against measurement, compound 4: 1.2-fold (0.07 log units) above, and the stated range covers the measured number.
By their numbers in this assay, from the lowest: compound 3; then compound 4; then compound 1; then compound 2.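

In this assay, the step of a 3.8-fold higher number from compound 3 to compound 4 (0.58 log units; beyond the scatter) is the first reading of a change in one place among these compounds, and it lies beyond the scatter, so the group on this aromatic carbon does affect the number. Still, the step is modest: amino, with one heavy atom and a hydrogen-bond donor, is tolerated here in place of cyano, with its two heavy atoms, triple bond and no donor. Nothing shown here accounts for the size or direction of this step.

The compounds shown leave open how a hydroxyl, a methoxy group, a carboxylic acid or an acetamide would fare on this same carbon. They also leave open whether the step from cyano to amino would keep its size on another core.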